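Halogen swap on the aryl amide of compound 3

This account rests on a few compounds, and the source may have more. Where it says the series, first, only, none or still open, it means among the compounds named here.

Measured in a functional assay on HL-60 cells (Homo sapiens) for antiproliferative activity, read by MTT assay, with a stated time of 72 h; a lower number here means a stronger inhibitor, a higher number a weaker inhibitor:
compound 1 `CC(=O)N(C)c1ccc2[nH]c(-c3n[nH]c4ccccc34)cc2n1`: 5110 nM
compound 2 `CN(C(=O)C(C)(C)C)c1ccc2[nH]c(-c3n[nH]c4ccccc34)cc2n1`: 4990 nM
compound 3 `CN(C(=O)c1ccc(F)cc1)c1ccc2[nH]c(-c3n[nH]c4ccccc34)cc2n1`: 1210 nM

Compound 3 stands lowest of the three numbers in this assay and is the strongest inhibitor of the set: the steps of a 4.2-fold lower number from compound 1 to compound 3 (0.63 log units; beyond the scatter) and a 4.1-fold lower number from compound 2 to compound 3 (0.62 log units; beyond the scatter) both lie beyond the scatter, whereas a 1.0-fold lower number from compound 1 to compound 2 (0.01 log units; within the scatter) lies within it. The two alkyl amides sit together, and the 4-fluorophenyl amide sits apart from them.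

Compound 4 `CN(C(=O)c1ccc(Br)cc1)c1ccc2[nH]c(-c3n[nH]c4ccccc34)cc2n1` differs from compound 3 in one place: bromo in place of fluoro on an aromatic carbon. Among the compounds with values here, none of the measured steps alters a substituent on the aryl ring; all three exchange the whole group on the carbonyl carbon. The steps from the alkyl amides to compound 3 show that the aryl amide is the better choice here, but they give no reading on a halogen exchange within that aryl ring. Within the data shown here, with no precedent for this change, the expectation for compound 4 is a step in this assay of no more than the scatter, in either direction, a 1.2-fold lower number from compound 3 to compound 4 (0.08 log units; within the scatter). Compound 4 is therefore estimated at 1000 nM in this assay, with a range of 400 nM to 2500 nM.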

Compound 4, half-maximal inhibitory concentration: 1080 nM
Compound 4: middle estimate off by 1.1-fold (0.03 log units), on the low side; measured number inside the range.
By their numbers in this assay, from the lowest: compounds 4 and 3 (each within the scatter of the next); then compounds 2 and 1 (each within the scatter of the next).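

In this assay, within the data shown here, this is the first reading of an exchange on the aryl ring itself: bromo in place of fluoro on an aromatic carbon, para to a large group, gives a 1.1-fold lower number from compound 3 to compound 4 (0.05 log units; within the scatter), so the two halogens cannot be told apart at this position. The separation of the aryl amides from the alkyl amides therefore does not rest on fluoro alone, since a 4.6-fold lower number from compound 2 to compound 4 (0.66 log units; beyond the scatter) and a 4.7-fold lower number from compound 1 to compound 4 (0.67 log units; beyond the scatter) are both beyond the scatter, as were the corresponding steps to the 4-fluorophenyl amide, and none of these four compounds goes against that split. No measurement is available that accounts for this result or bears on the exchange of one halogen for the other.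

The compounds shown test only two halogens at this one ring position, so it remains open whether the reading would hold for an amine, a carboxylic acid or a methoxy group there, or for a halogen placed elsewhere on the ring. Also open, on these data alone, is whether a longer alkyl chain on the carbonyl, or a hydrogen in place of the methyl on the amide nitrogen, would keep a compound with the aryl amides or with the alkyl amides.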